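Trifluoromethyl to Methoxymethyl: Expected Shift in Cytotoxicity

A few compounds are considered here, and "the series" means these few. Any claim that something is new, unique, unknown or untested is made for them only; others in the source may bear on it.

Compound 2 `CC(C)=CCOc1cc(Nc2nccc(C(F)(F)F)n2)ccc1Cl` shows the lowest number of the three measured in a functional assay on MT2 cells (Homo sapiens) for cytotoxicity, read by MTT assay (on this read-out higher numbers stand for lower toxicity in this test and lower numbers for higher toxicity in this test), giving 2500 nM. Compound 1 `CC(C)=CCOc1cc(Nc2nccs2)ccc1Cl` gives 26000 nM in this assay, and compound 3 `COc1ccnc(Nc2ccc(C)c(OCC=C(C)C)c2)n1` gives 41000 nM; both stand beyond the scatter from compound 2. Compound 4 `COCc1ccnc(Nc2ccc(Cl)c(OCC=C(C)C)c2)n1` has not yet been measured in this assay. It differs from compound 2 in one place: methoxymethyl in place of trifluoromethyl on an aromatic carbon. Among the measured compounds shown here, no step between measured compounds serves as a direct guide. Compound 3, which lacks the trifluoromethyl, gives 41000 nM in this assay, and a step upward from compound 2, beyond the scatter and toward lower toxicity, is therefore expected for compound 4. The estimate for compound 4 in this assay is 15000 nM, with a range from 5000 nM to 45000 nM. The expected step is a 6.0-fold higher number from compound 2 to compound 4 (0.78 log units; beyond the scatter).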

Compound 4, half-maximal cytotoxic concentration: > 25000 nM
Compound 4 ended at the assay's limit (the forecaster's own chance of this, stated with the estimate: 10%); middle value at least 1.6-fold (0.22 log units) away from the limit.
By their numbers in this assay, from the lowest: compound 2; then compounds 1 and 3 (each within the scatter of the next).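

Among the compounds shown here, replacing trifluoromethyl with methoxymethyl on this aromatic carbon next to the ring nitrogen gives the first direct reading of this position in this assay: the change brings an at least 10-fold higher number from compound 2 to compound 4 (1.00 log units; beyond the scatter), toward lower toxicity in this test. Compound 4 gives > 25000 nM, and this is a limit of the assay and not a number. Within this pair, the low number of compound 2 does not survive the loss of trifluoromethyl.

As far as these compounds go, whether a methyl, a chlorine or an amine at this place would give a similar number stays open. A single pair also leaves open whether the same change would act alike on another core.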